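The compounds below may be only part of what the source reports. "The series", "measured", "known", "first", "only" and "open" are said of these compounds alone.

Working notes on the series.

Going by the values given here, compound 1 `COCCn1cc(C(=O)C(=O)Nc2ccc(OC(F)(F)F)cc2)c2ccccc21` is the only member with a number in a functional assay on FaDu cells (Homo sapiens) for cytotoxicity, read by MTT assay, with a stated time of 72 h; a lower number here means that less compound is tolerated, a higher number that more compound is tolerated: compound 1 gives 487 nM. Compound 2 `COCCn1cc(C(=O)C(=O)Nc2ccc(OC)nc2)c2cc(Cl)ccc21` has a different core, and the difference between the two cores is not broken down here. In this assay compound 2 reaches only a limit, > 10000 nM. Compound 3 `COc1ccc(NC(=O)C(=O)c2cn(C(C)C)c3ccc(Cl)cc23)cn1` differs from compound 2 by isopropyl in place of 2-methoxyethyl on an aromatic nitrogen. In this assay compound 3 likewise reaches only a limit, > 10000 nM. The step that the two limits leave unreadable from compound 2 to compound 3 therefore has no readable size, because the limit of > 10000 nM in this assay, at which 2 of the 3 values shown sit, hides whatever lies behind it.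

Compound 4 `CC(C)n1cc(C(=O)C(=O)Nc2ccc(OC(F)(F)F)cc2)c2ccccc21` is not yet measured in this assay. It relates to compound 1 as compound 3 relates to compound 2: isopropyl in place of 2-methoxyethyl on an aromatic nitrogen, the same change at the same place, seen twice in all within this set. Among the compounds with values here, the one measured instance of the change gives no size, so the expectation for compound 4 rests on a single anchor. For compound 4 the estimated step of a 1.6-fold higher number from compound 1 to compound 4 (0.22 log units; within the scatter) is taken as modest, within or just beyond the usual scatter, since neither direction is supported by a readable measured step. Compound 4 is expected near 800 nM, with a range from 200 nM to 3500 nM. That expectation leans on compound 1 at 487 nM and on nothing else. For compound 4 an outcome that is itself a limit rather than a number cannot be ruled out.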

Compound 4, concentration lethal to 50% of the cells: 8930 nM
Beside the measured number, compound 4's estimate is 11-fold (1.05 log units) below it, outside the stated range (above it).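

On the core of compound 1, isopropyl in place of 2-methoxyethyl on the aromatic nitrogen gives an 18-fold higher number from compound 1 to compound 4 (1.26 log units; beyond the scatter) in this assay, so this single pair shows a large step towards more compound being tolerated. The same change on the core of compound 2 cannot be read, because the pair compound 2 and compound 3 gives two limits and not two numbers: the limit of > 10000 nM in this assay, at which 2 of the 4 values shown sit. The step is therefore known on one core only, and the data neither confirm nor contradict that it carries over to the core of compound 2, nor do they give any reason for its size.

The compounds shown leave open which part of the change goes with the step, as 2-methoxyethyl and isopropyl differ both in the oxygen and in the branching, and a straight propyl chain on the same aromatic nitrogen would separate the two. Also open, from the compounds shown here alone, is how a longer chain ending in an amine or a carboxylic acid at that nitrogen would read in this assay, on the core of compound 1 and on the core of compound 2.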